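Benzanilide amides against HSP60/HSP10: toward the dibromo-hydroxyphenyl analogue

This account rests on a few compounds, and the source may have more. Where it says the series, first, only, none or still open, it means among the compounds named here.

Measured in an assay for inhibition of HSP60/HSP10 (Homo sapiens), with a stated time of 60 min; a higher number here means a weaker inhibitor, a lower number a stronger inhibitor:
Compound 1 `O=C(Nc1cccc(Cl)c1)c1cc(Br)cc(Br)c1` gives > 100000 nM, a limit of this assay.
Compound 2 `COc1c(Br)cccc1C(=O)Nc1ccc(Sc2nc3ccccc3s2)cc1` gives > 100000 nM, a limit.
Compound 3 `COc1c(Br)cccc1C(=O)Nc1ccc(Sc2nc3ccccc3s2)c(Cl)c1` gives > 100000 nM, a limit.

Compound 2 stands only at a limit in this assay, and the two other values shown are limits as well, so compound 2 cannot be ranked against them. Going by the values given here, the single one-place step, a step that the two limits leave unreadable from compound 2 to compound 3, is unreadable, both ends resting at the limit of > 100000 nM in this assay, at which 3 of the 3 values shown sit.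

Compound 4 `O=C(Nc1ccc(Sc2nc3ccccc3s2)cc1)c1cc(Br)cc(Br)c1O` differs from compound 2 by a group of 9 heavy atoms (6 carbon, 1 oxygen, 2 bromine; one six-membered aromatic ring of carbon only) in place of a group of 9 heavy atoms (7 carbon, 1 oxygen, 1 bromine; one six-membered aromatic ring of carbon only), on a carbonyl carbon. Among the compounds with values here, no measured step bears on this change, and the one step available gives no size. Compound 4 is therefore expected to remain near the limit, the expected step being a number no higher from compound 2 to compound 4 (the limit leaves the size open). The estimate for compound 4 is 100000 nM, between 20000 nM and 300000 nM.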

Compound 4, half-maximal inhibitory concentration: 4700 nM
The estimate for compound 4 lay 21-fold (1.33 log units) above the measured number; measured number outside the range, below it.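

In this assay, going by these compounds alone, a change on the carbonyl carbon gives the first readable number of the series: the 3,5-dibromo-2-hydroxyphenyl group brings an at least 21-fold lower number from compound 2 to compound 4 (1.32 log units; beyond the scatter). This change therefore moves the series off the limit, which neither the chloro step nor the other compounds shown could do. The step is only a bound, with its starting value a limit: the limit of > 100000 nM in this assay, at which 3 of the 4 values shown sit.

The compounds shown do not separate the hydroxy group from the added bromine as the source of the step. From the compounds shown here alone, how an amine or a carboxylic acid would read in place of the hydroxy group also stays open.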